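This account rests on a few compounds, and the source may have more. Where it says the series, first, only, none or still open, it means among the compounds named here.

Working notes on the series. For the measured compounds named here, three compounds share one core; the only variation is the group on the aromatic carbon of the five-membered ring. Compound 1 `CCN(CC)c1ccc(NC(=O)c2c(-c3c(Cl)cccc3Cl)noc2C(C)C)cc1` gives 150 nM in an in vitro assay on CHO-K cells with growth hormone secretagogue receptor type 1 (Homo sapiens) as the target (on this read-out higher numbers stand for weaker inhibition and lower numbers for stronger inhibition), the highest of the three numbers. Compound 2 `CCN(CC)c1ccc(NC(=O)c2c(-c3c(Cl)cccc3Cl)noc2CCC2CCCCO2)cc1` gives 39 nM in this assay, and compound 3 `CCN(CC)c1ccc(NC(=O)c2c(-c3c(Cl)cccc3Cl)noc2CCC2OCCO2)cc1` gives 25 nM. Compound 4 `CCN(CC)c1ccc(NC(=O)c2c(-c3c(Cl)cccc3Cl)noc2CCC2CCCO2)cc1` is not yet measured; its change from compound 1 is 2-(oxolan-2-yl)ethyl in place of isopropyl on an aromatic carbon. Both measured steps from compound 1 bear on it: a 3.8-fold lower number from compound 1 to compound 2 (0.59 log units; beyond the scatter) and a 6.0-fold lower number from compound 1 to compound 3 (0.78 log units; beyond the scatter), whereas a 1.6-fold lower number from compound 2 to compound 3 (0.19 log units; within the scatter). The new group is close in kind to both, so in this assay a step of about a 4.7-fold lower number from compound 1 to compound 4 (0.67 log units; beyond the scatter) is expected. The estimate for compound 4 is 32 nM, with a range from 15 nM to 70 nM.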

Compound 4, half-maximal inhibitory concentration: 57 nM
Compound 4: middle estimate off by 1.8-fold (0.25 log units), on the low side, and the stated range covers the measured number.
By their numbers in this assay, from the lowest: compounds 3, 2 and 4 (each within the scatter of the next, the first and the last beyond it); then compound 1.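

With a 2.6-fold lower number from compound 1 to compound 4 (0.42 log units; beyond the scatter) for 2-(oxolan-2-yl)ethyl in place of isopropyl, a third ring-bearing chain on this aromatic carbon also gives a lower number. The ring at the chain end now separates one pair: a 2.3-fold higher number from compound 3 to compound 4 (0.36 log units; beyond the scatter) sets oxolan-2-yl apart from 1,3-dioxolan-2-yl, whereas a 1.5-fold higher number from compound 2 to compound 4 (0.16 log units; within the scatter) leaves oxolan-2-yl and oxan-2-yl unseparated. Nothing available explains that gap.

The compounds shown leave open how a 2-cyclopentylethyl group, with an all-carbon ring, or a plain pentyl chain would compare on this carbon. They also leave open whether an amine at the chain end would keep the lower numbers.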